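Distal Aryl Swaps and an Unchanged Acid Dissociation Constant

The source may report more compounds than this note shows. Statements on the series, on what has been measured and on what is new or still open speak of the compounds shown alone.

Three compounds have been measured in a physicochemical assay for acid dissociation:

Compound 1 `COc1ccc(F)cc1CNCCCNc1ccnc2cc(C3CCCCC3)ccc12`: 9.47
Compound 2 `COc1ccc(F)cc1CNCCCNc1ccnc2cc(CCc3ccccc3)ccc12`: 9.47
Compound 3 `COc1ccc(F)cc1CNCCCNc1ccnc2cc(Cc3ccc(F)cc3)ccc12`: 9.47

Compound 3 stands level with compounds 1 and 2 at the digits printed, within the scatter of both. The three steps among the measured compounds all lie within the scatter: no change at the digits printed from compound 1 to compound 2 (within the scatter), no change at the digits printed from compound 1 to compound 3 (within the scatter) and no change at the digits printed from compound 2 to compound 3 (within the scatter). Each of these steps exchanges the group on the same aromatic carbon of the shared core, and none moves the read-out.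

Compound 4 `COc1ccc(F)cc1CNCCCNc1ccnc2cc(-c3ccc(F)cc3)ccc12` differs from compound 3 at that same carbon: 4-fluorophenyl in place of 4-fluorobenzyl on an aromatic carbon. All three measured steps bear on this change, since each alters only the group at this position, and each was flat. Compound 4 is therefore expected to show a number 0.02 log units lower from compound 3 to compound 4 (within the scatter), no change beyond the scatter. The estimate for compound 4 is 9.45, with a range from 9.15 to 9.75.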

Compound 4, acid dissociation constant: 9.47
For compound 4 the middle estimate is 0.02 log units below the measured one; the range from low to high includes it.
By their numbers in this assay, from the lowest: compounds 1, 2, 3 and 4 (each within the scatter of the next).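

In this assay, compound 4 is the only one of the four in which an aromatic ring is bound directly to this aromatic carbon, yet the swap of 4-fluorobenzyl for 4-fluorophenyl gives no change at the digits printed from compound 3 to compound 4 (within the scatter). The comparisons with the other two groups read the same, with no change at the digits printed from compound 2 to compound 4 (within the scatter) and no change at the digits printed from compound 1 to compound 4 (within the scatter), so the flat result at this position now extends to a group with no saturated carbon at the point of attachment. Nothing available accounts for this lack of response.

The compounds shown leave open whether an amine or a carboxylic acid on this same carbon would shift the number in this assay. They also leave open which site in these molecules gives up the proton, and whether a change to the fluorinated methoxybenzyl group or the propyl chain would be felt.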